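The source may hold more compounds than are shown below. What is called first, only, known or untested is meant among the compounds shown, and "the series" means these compounds.

Going by the values given here, in a functional assay on LoVo cells (Homo sapiens) for inhibition, read by MTT assay, with a stated time of 48 h (a lower number here means a stronger inhibitor, a higher number a weaker inhibitor), compound 1 (`COc1ccc(N(C)c2nc(C)nc3ccccc23)cc1OCCCCCC[Se]C#N`) gives 8580 nM, the higher of the two numbers so far. Compound 2 (`Cc1nc(N(C)c2ccc([Se]C#N)c(C)c2)c2ccccc2n1`) gives 19 nM, and that gap lies well beyond the scatter. Compound 3 (`COc1ccc(N(C)c2nc(C)nc3ccccc23)cc1`) strips the long selenium-containing chain from compound 1, leaving only a hydrogen atom on the aromatic carbon: a hydrogen atom in place of a group of 10 heavy atoms (7 carbon, 1 nitrogen, 1 oxygen, 1 selenium; no ring), on an aromatic carbon. Among the compounds with values here, no measured pair shows this change directly, but compound 2, which has no such long chain, gives 19 nM, so a strong gain is expected. The expected change is a 430-fold lower number from compound 1 to compound 3 (2.63 log units; beyond the scatter), a large fall beyond the scatter. For compound 3, the estimated value is 20 nM, within an expected range of 3 nM to 150 nM.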

Compound 3, half-maximal inhibitory concentration: 8 nM
For compound 3 the middle estimate is 2.5-fold (0.40 log units) above the measured one, and the stated range covers the measured number.
By their numbers in this assay, from the lowest: compound 3; then compound 2; then compound 1.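

Putting a hydrogen atom in place of the long selenium-containing chain on this aromatic carbon gives a 1100-fold lower number from compound 1 to compound 3 (3.03 log units; beyond the scatter) in this assay and shows directly that this chain costs a great deal of activity on the shared core. Compound 3 also shows that a low number here needs no selenium at all. No measurement at hand explains the size of this change.

From the compounds shown here alone, what a short chain, such as an ethoxy group, or an amine would do at this position stays open. So does whether the loss follows from the chain's length or from its selenium-bearing end.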